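Cyano in place of methylsulfanyl: working notes

The compounds below may be only part of what the source reports. "The series", "measured", "known", "first", "only" and "open" are said of these compounds alone.

Measured in a functional assay on U-87MG ATCC cells for inhibition, with U-87 MG (Homo sapiens) as the target, read by MTT assay, with a stated time of 48 h; a lower number here means a stronger inhibitor, a higher number a weaker inhibitor:
Compound 1 `CS(=O)(=O)c1ccc(-c2nc3ccccn3c2Sc2ccccc2)cc1` gives 77200 nM
Compound 2 `CSc1ccc(-c2nc3ccccn3c2Sc2ccccc2)cc1` gives 26900 nM

Going by the values given here, compound 2 holds the lower of the two numbers so far. The next entry is compound 3 `N#Cc1ccc(-c2nc3ccccn3c2Sc2ccccc2)cc1`, with cyano in place of methylsulfanyl on an aromatic carbon, para to a large group: cyano in place of methylsulfanyl on an aromatic carbon. Among the compounds with values here, only one measured step bears on this change, a 2.9-fold lower number from compound 1 to compound 2 (0.46 log units; beyond the scatter), a modest step beyond the scatter that also concerns the methylsulfanyl group. Within the data shown here, no measured compound carries cyano, so the evidence is indirect. In this assay, a step toward a higher number is expected, similar in size to that one or smaller. The estimated step is a 1.9-fold higher number from compound 2 to compound 3 (0.27 log units; within the scatter). The estimate for compound 3 is 50000 nM, with an expected range of 18000 nM to 120000 nM.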

Compound 3, half-maximal inhibitory concentration: 65500 nM
Compound 3: middle estimate off by 1.3-fold (0.12 log units), on the low side; the measured number falls inside the stated range.
By their numbers in this assay, from the lowest: compound 2; then compounds 3 and 1 (each within the scatter of the next).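

In this assay the change from 4-(methylsulfanyl)phenyl to 4-cyanophenyl gives a 2.4-fold higher number from compound 2 to compound 3 (0.39 log units; beyond the scatter), so compound 2 now holds the lower number against two different replacements at this position, where before there was only one. Cyano and methylsulfonyl are not separated here, with a 1.2-fold lower number from compound 1 to compound 3 (0.07 log units; within the scatter), which leaves methylsulfanyl as the only group shown at this position to stand apart from the others. The data at hand offer no explanation for either step.

As far as these compounds go, it remains open whether an amine, a methoxy group or a longer chain such as ethylsulfanyl at this position would give a number lower than that of compound 2. From the compounds shown here alone, it also remains open whether the gap between methylsulfanyl and cyano would persist with changes elsewhere on the shared core.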